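The compounds below may be only part of what the source reports. "The series", "measured", "known", "first", "only" and "open" are said of these compounds alone.

Measured so far in an assay for inhibition of 15-hydroxyprostaglandin dehydrogenase [NAD(+)] (Homo sapiens), read by fluorescence and spectrophotometry; on this read-out lower numbers stand for stronger inhibition and higher numbers for weaker inhibition:
Compound 1 `O=C1N=C(O)S/C1=C\c1ccc(OCCC2CCCCC2)cc1Cl` gives 13 nM.
Compound 2 `O=C1N=C(O)S/C1=C\c1ccc(OCCc2ccccn2)cc1Cl` gives 8920 nM.

Compound 2 holds the higher of the two numbers, and the step of a 690-fold higher number from compound 1 to compound 2 (2.84 log units; beyond the scatter) shows that number rising sharply when pyridin-2-yl replaces cyclohexyl. Compound 3 `O=C1N=C(O)S/C1=C\c1ccc(OCc2ccccc2)cc1Cl` differs from compound 2 by phenyl in place of (pyridin-2-yl)methyl on a saturated chain carbon bound to an oxygen on an aromatic ring. Within the data shown here, the only step at hand is a 690-fold higher number from compound 1 to compound 2 (2.84 log units; beyond the scatter), and it bears on this change in reverse: the ring with a nitrogen leaves and a carbon-only ring enters, though the chain is also one carbon shorter. A large fall in the number is therefore expected, a 45-fold lower number from compound 2 to compound 3 (1.65 log units; beyond the scatter), with compound 3 estimated at 200 nM, in a range from 30 nM to 1500 nM.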

Compound 3, half-maximal inhibitory concentration: 487 nM
Compound 3: middle estimate off by 2.4-fold (0.39 log units), on the low side; low and high end bracket the measured number.
By their numbers in this assay, from the lowest: compound 1; then compound 3; then compound 2.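

In this assay, moving from 2-(pyridin-2-yl)ethyl to benzyl gives an 18-fold lower number from compound 2 to compound 3 (1.26 log units; beyond the scatter), so an aromatic ring at this position does not carry the full loss seen with the pyridin-2-yl group. Benzyl still falls well short of the cyclohexyl-ended chain, with a 37-fold higher number from compound 1 to compound 3 (1.57 log units; beyond the scatter). No measured evidence here explains either step. From the compounds shown here alone, this change removes the ring nitrogen and shortens the chain at once, so the share of each remains open. A 2-phenylethyl group at this position would separate the two.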